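A few compounds are considered here, and "the series" means these few. Any claim that something is new, unique, unknown or untested is made for them only; others in the source may bear on it.

The series starts from compound 1 `O=C(O)/C=C/c1ccncc1-c1ccc2ccccc2c1`, a carboxylic acid, and its primary amide, compound 2 `NC(=O)/C=C/c1ccncc1-c1ccc2ccccc2c1`, which shares the core of compound 1. Both were tested in a functional assay on MDA-MB-231 cells (Homo sapiens) for inhibition, read by sulforhodamine B assay, with a stated time of 72 h; on this read-out lower numbers stand for stronger inhibition of growth and higher numbers for weaker inhibition of growth. Compound 1 gives > 10000 nM, which is a limit of the assay and not a number. Compound 2 gives > 10000 nM, which is likewise a limit. Compound 2 therefore has no measured position of its own, and the record so far is the limit of > 10000 nM in this assay, at which 2 of the 2 values shown sit.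

The next change leads to compound 3 `CN(C)C(=O)/C=C/c1ccncc1-c1ccc2ccccc2c1`, with dimethylamino in place of amino on a carbonyl carbon. For the measured compounds named here, the only measured step that bears on it is a step that the two limits leave unreadable from compound 1 to compound 2, a change at the same carbonyl carbon, and it has no readable size. It therefore gives no sign of any gain in this assay, and no shift beyond the scatter is expected. The expected move is a step that the limit leaves unreadable from compound 2 to compound 3. For compound 3 the estimate is 12000 nM, with an expected range from 5000 nM to 30000 nM, and the assay may well report only a limit again.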

Compound 3, concentration for 50% growth inhibition: 7990 nM
The estimate for compound 3 lay 1.5-fold (0.18 log units) above the measured number; the measured number falls inside the stated range.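

For the compounds shown here, compound 3 is the first compound to give a number instead of a limit in this assay, and it does so with dimethylamino on the carbonyl carbon, where the hydrogen-bond donor of the amino group is gone. At this carbonyl carbon the record now holds an at least 1.2-fold lower number from compound 2 to compound 3 (0.09 log units; that floor lies within the scatter), and it also holds an at least 1.2-fold lower number from compound 1 to compound 3 (0.09 log units; that floor lies within the scatter), so a number has been reached at this position, but no change beyond the scatter has been shown. The earlier step between the two limits still cannot be read, and limits still make up most of the record: the limit of > 10000 nM in this assay, at which 2 of the 3 values shown sit.

The compounds shown leave open whether methylamino, diethylamino or a cyclic amine such as pyrrolidine on the same carbonyl carbon would move the number further, and whether a longer chain in place of the two methyl groups would do the same. Going by these compounds, the true size of the step from amino to dimethylamino also stays open, as compound 2 has a limit and no number.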